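The source may report more compounds than this note shows. Statements on the series, on what has been measured and on what is new or still open speak of the compounds shown alone.

Measured so far:
compound 1, `CN1CCN(c2cc(N)c3ccccc3n2)CC1`, gives 1.45 nM in an assay on HEK293 cells for displacement of a labelled ligand from 5-hydroxytryptamine receptor 3A (Homo sapiens), read by scintillation counting, with a stated time of 24 h, in the presence of a further agent that is not named here; on this read-out lower numbers stand for stronger inhibition and higher numbers for weaker inhibition.
compound 2, `CNc1cc(N2CCN(C)CC2)nc2ccccc12`, gives 13.5 nM in this assay.
compound 3, `CN1CCN(c2cc3ccccc3c(N)n2)CC1`, gives 219 nM in this assay.

Compound 1 and compound 2 share a core and differ in one place: methyl in place of hydrogen on a nitrogen on an aromatic ring. In this assay this change is recorded as a 9.3-fold higher number from compound 1 to compound 2 (0.97 log units; beyond the scatter). Compound 3 is built from the same atoms as compound 1, joined differently; the difference between the two cores is not broken down here. In this assay compound 3 stands highest of the three, and its value lies beyond the scatter from both compound 1 and compound 2.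

Compound 4, `CNc1nc(N2CCN(C)CC2)cc2ccccc12`, is not yet measured. It stands to compound 3 as compound 2 stands to compound 1: methyl in place of hydrogen on a nitrogen on an aromatic ring. The place of the change is described in the same words for both pairs, so this is the same change made on a different core. Among the measured compounds shown here, because a 9.3-fold higher number from compound 1 to compound 2 (0.97 log units; beyond the scatter) was the outcome when this change was made once before, a step of similar size is expected here, although only one earlier instance is known and the core of compound 3 is different. For compound 4 the expected step is a 9.1-fold higher number from compound 3 to compound 4 (0.96 log units; beyond the scatter), set beside the measured 9.3-fold higher number from compound 1 to compound 2 (0.97 log units; beyond the scatter). Compound 4 is therefore estimated to give 2000 nM in this assay, with the range 600 nM to 6500 nM taken as likely.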

Compound 4, inhibition constant: 5.89 nM
Compound 4: the middle estimate sits 340-fold (2.53 log units) above what was measured; the whole stated range lies above it.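

In this assay, methyl in place of hydrogen on a nitrogen on an aromatic ring gives a 37-fold lower number from compound 3 to compound 4 (1.57 log units; beyond the scatter), a large step, and it does not repeat what the same change did on the core of compound 1: the same change on two cores in this assay, a 9.3-fold higher number (0.97 log units; beyond the scatter) from compound 1 to compound 2 and a 37-fold lower number (1.57 log units; beyond the scatter) from compound 3 to compound 4, 350-fold (2.54 log units) apart, beyond the scatter of two such steps. The two steps run in opposite directions, so on these two cores the result of going from amino to methylamino depends on the core that carries it, and the step measured on one core gave no usable guide to the step on the other. This does not show why the two cores part ways, and with a single pair on each core it does not show how the change would behave on a third core or which of the two outcomes would be the more usual one in this series.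

The compounds shown leave open whether an ethyl group, a longer chain or a second methyl on that same nitrogen would follow the direction seen on each core. They also leave open whether the opposite directions would persist with an acetyl group there in place of the methyl, since only hydrogen and methyl appear at this place on either core.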